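The source may report more compounds than this note shows. Statements on the series, on what has been measured and on what is new or still open speak of the compounds shown alone.

Among the compounds with values here, compound 2, with structure `N#Cc1ccc(NC(=O)C(=O)N2CCC(c3ccnc4ccc(F)cc34)CC2)cc1`, gives 36 nM in an assay on SK-OV-3 cells for inhibition of Indoleamine 2,3-dioxygenase 1 (Homo sapiens) (on this read-out lower numbers stand for stronger inhibition and higher numbers for weaker inhibition), the higher of the two numbers measured so far; compound 1, with structure `O=C(Nc1ccc(Cl)cc1)C(=O)N1CCC(c2ccnc3ccc(F)cc23)CC1`, gives 15 nM. Between them the only change, cyano in place of chloro on an aromatic carbon, produced a 2.4-fold higher number from compound 1 to compound 2 (0.38 log units; beyond the scatter). Compound 3, with structure `O=C(Nc1ccc(C(F)(F)F)cc1)C(=O)N1CCC(c2ccnc3ccc(F)cc23)CC1`, differs from compound 2 by trifluoromethyl in place of cyano on an aromatic carbon. Within the data shown here, no measured step covers trifluoromethyl, so only the modest movement seen between compound 1 and compound 2 at this position guides the expectation. For compound 3 a small step back toward lower numbers is expected, a 1.8-fold lower number from compound 2 to compound 3 (0.26 log units; within the scatter), giving an estimate of 20 nM with a range from 8 nM to 50 nM.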

Compound 3, half-maximal inhibitory concentration: 90 nM
For compound 3 the middle estimate is 4.5-fold (0.65 log units) below the measured one, outside the stated range (above it).
By their numbers in this assay, from the lowest: compound 1; then compound 2; then compound 3.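

In this assay the group at this place on the aromatic ring clearly matters: trifluoromethyl replacing cyano moves the number up (a 2.5-fold higher number from compound 2 to compound 3 (0.40 log units; beyond the scatter)), and trifluoromethyl replacing chloro moves it further (a 6.0-fold higher number from compound 1 to compound 3 (0.78 log units; beyond the scatter)). Three groups now fall in one order, with chloro lowest, cyano next and trifluoromethyl highest. Nothing available explains this order.

From the compounds shown here alone, whether an amine, a methoxy group or a carboxylic acid at this place would give a lower or higher number stays open, as does whether this order holds on a different core.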